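Single chlorine replaces the dichlorinated ring on the alkene

A few compounds are considered here, and "the series" means these few. Any claim that something is new, unique, unknown or untested is made for them only; others in the source may bear on it.

Compound 3 `O=C1/C(=C\c2c(Cl)cccc2Cl)c2ccccc2N1c1c(Cl)cccc1Cl` stands at a limit of a functional assay on B16-F10 cells (Homo sapiens) for cytotoxicity against B16-F10 (Mus musculus), read by MTT assay, with a stated time of 72 h (a lower number here means that less compound is needed, a higher number that more compound is needed for the effect), giving > 100 ug/mL. Compound 2 `O=C1/C(=C\c2ccc(Cl)cc2)c2ccccc2N1c1c(Cl)cccc1Cl` likewise reaches only a limit, with > 100 ug/mL. Compound 1 `O=C1/C(=C\c2ccc(F)cc2)c2ccccc2N1c1c(Cl)cccc1Cl` gives a numerical value, 38 ug/mL. The steps of an at least 2.6-fold higher number from compound 1 to compound 2 (0.42 log units; beyond the scatter) and an at least 2.6-fold higher number from compound 1 to compound 3 (0.42 log units; beyond the scatter) both end at the limit of > 100 ug/mL in this assay, at which 2 of the 3 values shown sit, while the step that the two limits leave unreadable from compound 2 to compound 3 cannot be read. Compound 4 `O=C1/C(=C\c2cccc(Cl)c2)c2ccccc2N1c1c(Cl)cccc1Cl` carries 3-chlorophenyl in place of 2,6-dichlorophenyl on a double-bonded chain carbon bound to a double-bonded ring carbon. For the measured compounds named here, no measured step reaches a single-chlorine ring of this kind, and since compound 3 gives only the limit > 100 ug/mL, the step of a number no higher from compound 3 to compound 4 (the limit leaves the size open) is expected to be unreadable or small. Compound 4 is therefore estimated at 100 ug/mL, within a range from 40 ug/mL to 300 ug/mL.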

Compound 4, concentration for half-maximal effect: 8 ug/mL
Compound 4: the middle estimate sits 13-fold (1.10 log units) above what was measured, and the stated range ends above it.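

In this assay, moving from a ring that reaches only the limit to 3-chlorophenyl, on a double-bonded chain carbon bound to a double-bonded ring carbon, gives an at least 12-fold lower number from compound 3 to compound 4 (1.09 log units; beyond the scatter) and an at least 12-fold lower number from compound 2 to compound 4 (1.09 log units; beyond the scatter). For the compounds shown here, the same group also gives a 4.8-fold lower number from compound 1 to compound 4 (0.68 log units; beyond the scatter), so a single chlorine here can outdo the only earlier compound with a numerical value. The first two steps start from limits, so their full size stays open: the limit of > 100 ug/mL in this assay, at which 2 of the 4 values shown sit.

On these data alone, whether a nitrile or an amine in place of that chlorine would keep the lower number remains open. These compounds show the size of the change. They show nothing more about it.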